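A Cyclopropylmethyl Amine Variant of a Urea with a High Inhibition Number

The source may hold more compounds than are shown below. What is called first, only, known or untested is meant among the compounds shown, and "the series" means these compounds.

Measured compounds:
compound 1 `CCNc1cc(-c2ccc(NC(=O)Nc3cccc(Cl)c3)cc2C(F)(F)F)ccn1`: 94.9%
compound 2 `CCNc1cc(-c2ccc(NC(=O)Nc3ccc(OC)cc3)cc2C(F)(F)F)ccn1`: 62.1%
compound 3 `CCNc1cc(-c2ccc(NC(=O)Nc3ccc(C(F)(F)F)cc3)cc2C(F)(F)F)ccn1`: 82.9%

Compound 1 stands highest of the three numbers in an assay on isolated protein for inhibition of serine/threonine-protein kinase PLK1 (Homo sapiens), read by radiometric assay and 33P incorporation, with a stated time of 40 min, tested at 20 uM, in the presence of a further agent that is not named here; a lower number here means less inhibition, a higher number more inhibition at the concentration tested (going by the name of the read-out); the nearest step down is a number 12 percentage points lower from compound 1 to compound 3 (beyond the scatter) and the furthest is a number 32.8 percentage points lower from compound 1 to compound 2 (beyond the scatter). Compound 4 `O=C(Nc1cccc(Cl)c1)Nc1ccc(-c2ccnc(NCC3CC3)c2)c(C(F)(F)F)c1` differs from compound 1 in one place: cyclopropyl in place of methyl on a saturated chain carbon bound to a nitrogen on an aromatic ring. Every measured step, including a number 20.8 percentage points higher from compound 2 to compound 3 (beyond the scatter), changed the group on the amide-type nitrogen at the far end of the molecule, so none of them bears on this position, and the data give no guide for it. In the absence of such a guide, compound 4 is expected to stay close to compound 1, with a step of a number 4.9 percentage points lower from compound 1 to compound 4 (within the scatter) in this assay estimated to fall within the scatter. The estimate for compound 4 is 90%, ranging from 75% to 98%.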

Compound 4, a percentage reported as inhibition, at one concentration (the size of the read-out at that concentration, not a potency): 63.8%
Estimate against measurement, compound 4: 26.2 percentage points above; the whole stated range lies above it.
By their numbers in this assay, from the lowest: compounds 2 and 4 (each within the scatter of the next); then compound 3; then compound 1.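

For the compounds shown here, until now only the group on the far amide-type nitrogen had changed, so this is the first sign that the other end of the molecule also affects the number. In this assay, replacing methyl with cyclopropyl on a saturated chain carbon bound to a nitrogen on an aromatic ring gives a number 31.1 percentage points lower from compound 1 to compound 4 (beyond the scatter), a large loss from a small change. Nothing measured here gives a reason for this loss. A propyl or butyl chain at this nitrogen could show whether the ring itself matters or simply the added carbons. On these data alone, whether the loss also appears with 4-methoxyphenyl at the far end remains open.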